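Swapping the urea aryl group in a shared core

The source may hold more compounds than are shown below. What is called first, only, known or untested is meant among the compounds shown, and "the series" means these compounds.

Measured in a functional assay on MDA-MB-231 cells (Homo sapiens) for antiproliferative activity, read by MTT assay, with a stated time of 72 h; a higher number here means a weaker inhibitor, a lower number a stronger inhibitor:
compound 1 `CC(=O)Nc1ccc(S(=O)(=O)Nc2cccc(-c3nc(-c4ccc(NC(=O)c5cccnc5)cc4)no3)c2)cc1` gives 5200 nM
compound 2 `CC(=O)Nc1ccc(S(=O)(=O)Nc2cccc(-c3nc(-c4ccc(NC(=O)c5cccnc5)cc4C(F)(F)F)no3)c2)cc1` gives a limit, > 10000 nM
compound 3 `Cc1ccc(NC(=O)Nc2cccc(-c3nc(-c4ccc(NC(=O)c5cccnc5)cc4Cl)no3)c2)cc1` gives 3500 nM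

Compound 3 holds the lowest of the two numbers, yet its gap to compound 1 lies within the scatter, so the two cannot be ranked against each other. Compound 2 is reported only as a limit, not a number (the limit of > 10000 nM in this assay, at which 1 of the 3 values shown sits).

Compound 4 `CC(=O)Nc1ccc(NC(=O)Nc2cccc(-c3nc(-c4ccc(NC(=O)c5cccnc5)cc4Cl)no3)c2)cc1Cl` differs from compound 3 in a single place: 4-acetamido-3-chlorophenyl in place of 4-methylphenyl on an amide-type nitrogen. Among the compounds with values here, the only measured step, an at least 1.9-fold higher number from compound 1 to compound 2 (0.28 log units; that floor lies within the scatter), alters a different part of the shared core and leaves this nitrogen untouched, so no measured step speaks to the present change. The other pair, compound 1 and compound 3, differs in more than one place and gives values within the scatter of each other.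

With nothing to point either way, compound 4 is expected to show a 1.1-fold lower number from compound 3 to compound 4 (0.04 log units; within the scatter), a step within the scatter. The estimated value for compound 4 in this assay is 3200 nM, in the range 1200 nM to 8500 nM.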

Compound 4, half-maximal inhibitory concentration: > 10000 nM
Compound 4: only a limit was reported; the forecaster's own chance of this, stated with the estimate: 15%; middle value at least 3.1-fold (0.49 log units) away from the limit.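

In this assay, the group on this amide-type nitrogen matters: replacing 4-methylphenyl with 4-acetamido-3-chlorophenyl gives an at least 2.8-fold higher number from compound 3 to compound 4 (0.45 log units; beyond the scatter). Within the data shown here, this is the first measured change at this nitrogen, and it shows that the shared core does not keep its antiproliferative activity with every aryl group placed here. Compound 4 is reported only as a limit, not a number, the same limit that compound 2 carries: the limit of > 10000 nM in this assay, at which 2 of the 4 values shown sit.

The incoming group brings the chlorine and the acetamido group together, so the compounds shown cannot say which of the two accounts for the step. Going by these compounds, it remains open how a phenyl carrying only chlorine or only acetamido would behave on this nitrogen, or how a phenyl carrying an amine or a carboxylic acid would.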